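Aryl substituent change on the piperazine end of the series

The source may hold more compounds than are shown below. What is called first, only, known or untested is meant among the compounds shown, and "the series" means these compounds.

Of the compounds shown here, three have been measured in an assay on HEK293 cells for inhibition of Voltage-dependent T-type calcium channel subunit alpha-1G (Homo sapiens), read by fluorescence, tested at 10 uM; on this read-out higher numbers stand for more inhibition at the one concentration tested (going by the name of the read-out) and lower numbers for less inhibition. Compound 1 `CCCc1nc(-c2ccccc2)c(CNCCN2CCN(c3ccccc3F)CC2)o1` gives 46.5%. Compound 2 `Cc1nc(-c2ccccc2)c(CNCCCN2CCN(c3ccc(Cl)cc3)CC2)o1` gives 38.1%, and compound 3 `CCCc1nc(-c2ccccc2)c(CNCCCN2CCN(c3cccc(Cl)c3)CC2)o1` gives 65.9%. Among these three numbers compound 1 stands second highest; its gap to compound 2 lies within the scatter, so no order between those two can be read, while compound 3 stands beyond the scatter above compound 1. Within the data shown here, compounds 2 and 3 each differ from compound 1 in more than one place, so no single step between measured compounds is known in this set.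

Among the measured compounds shown here, compound 4 `CCCc1nc(-c2ccccc2)c(CNCCN2CCN(c3ccccc3C(F)(F)F)CC2)o1` is the one compound not yet measured. It departs from compound 1 by trifluoromethyl in place of fluoro on an aromatic carbon, on an aromatic carbon of the six-membered aromatic ring of carbon only; the rest of the molecule is kept as in compound 1.

For the measured compounds named here, no measured pair isolates this change, so the expectation rests on little. The expected step is a number 3.5 percentage points higher from compound 1 to compound 4 (within the scatter), small and not clearly beyond the scatter in either direction. Compound 4 is therefore estimated at 50% in this assay, with a range from 25% to 75%.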

Compound 4, a percentage reported as inhibition, at one concentration (the size of the read-out at that concentration, not a potency): 54.6%
Compound 4: the middle estimate sits 4.6 percentage points below what was measured; measured number inside the range.
By their numbers in this assay, from the lowest: compounds 2, 1 and 4 (each within the scatter of the next, the first and the last beyond it); then compound 3.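

In this assay, among these compounds, the change from 2-fluorophenyl to 2-(trifluoromethyl)phenyl gives a number 8.1 percentage points higher from compound 1 to compound 4 (within the scatter), the first step in this set that isolates a single place. At this aromatic carbon, ortho to a large group, four heavy atoms of trifluoromethyl replace the one of fluoro with no step beyond the scatter, so the larger substituent is accommodated on this read-out, and the added bulk neither clearly gains nor clearly loses inhibition at the one concentration tested. No measurement available here speaks to the reason for the size of this step.

The compounds shown leave open whether a methoxy group or a nitrile on the same aromatic carbon would also stay within the scatter of compound 1, or whether a substituent of another kind would produce a step beyond it. Going by these compounds, it also remains open whether trifluoromethyl in place of fluoro would give a similar step on a compound with a longer chain between the amine and the piperazine, since this change is known on one background only.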